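This account rests on a few compounds, and the source may have more. Where it says the series, first, only, none or still open, it means among the compounds named here.

Measured so far:
- compound 1, `Nc1ccccc1NC(=O)c1ccc(CSC(=S)N2CCN(C3CCCCC3)CC2)cc1`: 76.1%
- compound 2, `Nc1ccccc1NC(=O)c1ccc(CSC(=S)N2CCc3cc([N+](=O)[O-])ccc32)cc1`: 43.6%
- compound 3, `CC1CCCCN1C(=S)SCc1ccc(C(=O)Nc2ccccc2N)cc1`: 76.3%

In a functional assay on HeLa cells (Homo sapiens) for antiproliferative activity, read by CCK-8 assay, with a stated time of 72 h, tested at 8 uM (a lower number here means a weaker effect, a higher number a stronger effect of the compound at the concentration tested), compound 3 stands highest of the three numbers; compound 1 lies within the scatter of it, while compound 2 lies well beyond the scatter below it. Going by the values given here, no step between measured compounds is available, so the size of the move to compound 4, `CN(Cc1cccnc1)C(=S)SCc1ccc(C(=O)Nc2ccccc2N)cc1`, rests on the structural change alone: methyl((pyridin-3-yl)methyl)amino in place of 2-methylpiperidin-1-yl on a thiocarbonyl carbon. A moderate downward step is expected for compound 4 from compound 3, a number 12.3 percentage points lower from compound 3 to compound 4 (beyond the scatter), since the two high numbers belong to compounds 1 and 3 and the change here leaves that pattern. Compound 4 is estimated at 64%, with a range from 44% to 82%.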

Compound 4, a percentage reported as inhibition, at one concentration (the size of the read-out at that concentration, not a potency): 68.7%
Estimate against measurement, compound 4: 4.7 percentage points below; the measured number falls inside the stated range.
By their numbers in this assay, from the lowest: compound 2; then compounds 4, 1 and 3 (each within the scatter of the next).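

Exchanging 2-methylpiperidin-1-yl for methyl((pyridin-3-yl)methyl)amino on the thiocarbonyl carbon gives, in this assay, a number 7.6 percentage points lower from compound 3 to compound 4 (within the scatter). Going by these compounds alone, this is the first one-place comparison, and it shows that this position accepts a six-membered aromatic ring with one hetero atom, carried on a non-ring amine nitrogen, in place of a non-aromatic ring without a change beyond the scatter. No measured property is available to explain the step.

From the compounds shown here alone, whether the pyridine nitrogen matters remains open, and benzyl(methyl)amino would test this directly. Unsubstituted piperidin-1-yl and morpholin-4-yl on the same carbon are also open.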